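The source may hold more compounds than are shown below. What is called first, only, known or untested is meant among the compounds shown, and "the series" means these compounds.

Measured compounds:
compound 1, `CC(C)(C)C1=NN(c2ccc(C(=O)O)cc2)C(c2ccc(O)cc2)C1`, inhibition 47.9%
compound 2, `CC(C)(C)C1=NN(c2ccccc2F)C(c2ccc(O)cc2)C1`, inhibition 57.6%

Of the compounds shown here, two have been tested in an assay on isolated protein for inhibition of protein kinase C zeta type (Homo sapiens), with a stated time of 4 min, tested at 62.5 uM; a lower number here means less inhibition, a higher number more inhibition at the concentration tested (going by the name of the read-out). Compound 1 gives 47.9% and compound 2 gives 57.6%. Compound 2 has the higher of the two numbers, but the gap to compound 1 is within the usual scatter of this assay, so the two values cannot be told apart and neither compound can be said to have the higher inhibition in this assay.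

The next compound, compound 3, `CC(C)(C)C1=NN(c2ccc(O)cc2)C(c2ccc(O)cc2)C1`, has not yet been measured. It differs from compound 2 in one place: 4-hydroxyphenyl in place of 2-fluorophenyl on an amine nitrogen in a ring. Among the measured compounds shown here, no step between measured compounds that matches this change is available, so there is nothing in the data to say which way the change should move the read-out. Both measured compounds sit in the same middle band, and a new compound on the shared core is expected to do the same. The step of a number 5.6 percentage points lower from compound 2 to compound 3 (within the scatter) is expected to stay within the scatter, with no clear direction. Compound 3 is therefore expected to give about 52% in this assay, with a range from 32% to 72%.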

Compound 3, a percentage reported as inhibition, at one concentration (the size of the read-out at that concentration, not a potency): 40.9%
Beside the measured number, compound 3's estimate is 11.1 percentage points above it; the measured number falls inside the stated range.
By their numbers in this assay, from the lowest: compounds 3, 1 and 2 (each within the scatter of the next, the first and the last beyond it).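

In this assay, the change of 2-fluorophenyl to 4-hydroxyphenyl on the amine nitrogen in a ring gives a number 16.7 percentage points lower from compound 2 to compound 3 (beyond the scatter). Among the compounds shown here, this is the first step to pass the scatter, and it shows that the read-out can respond to the group at this position, which the two earlier values could not show. Hydroxy in place of carboxy on an aromatic carbon gives a number 7 percentage points lower from compound 1 to compound 3 (within the scatter), so this change does not separate the two compounds, and nothing measured here speaks to what lies behind either step.

The compounds shown leave open whether the step from the 2-fluorophenyl group follows from losing the fluorine, from gaining the hydroxy, or from both, and an unsubstituted phenyl or a 4-methoxyphenyl group on the same nitrogen would help to tell these apart. From the compounds shown here alone, all three compounds also share the tert-butyl and 4-hydroxyphenyl groups on the core, so how a cyclohexyl in place of tert-butyl, or an aminophenyl in place of that 4-hydroxyphenyl, would bear on the read-out remains open.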